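The compounds below may be only part of what the source reports. "The series", "measured", "known", "first", "only" and "open" are said of these compounds alone.

Compound 3 `CCC(C)(C)/N=c1\c(O)c(O)\c1=N/Cc1ccc(F)cc1` gives the lowest number of the three measured compounds in a functional assay for inhibition, with Rattus norvegicus as the target (on this read-out lower numbers stand for stronger inhibition and higher numbers for weaker inhibition), namely 360 nM. Compound 1 `CC[C@H](C)/N=c1\c(O)c(O)\c1=N/Cc1ccc(C#N)cc1` gives 2200 nM in this assay, and compound 2 `CC[C@@H](C)/N=c1\c(O)c(O)\c1=N/Cc1ccc(C#N)cc1` gives 4000 nM in this assay. The step of a 1.8-fold higher number from compound 1 to compound 2 (0.26 log units; within the scatter) lies within the scatter, in keeping with the fact that compounds 1 and 2 differ only in the configuration as drawn. Compound 4 `CCC(C)(C)/N=c1\c(O)c(O)\c1=N/Cc1ccc(C#N)cc1` is compound 3 with cyano in place of fluoro on an aromatic carbon. Going by the values given here, no measured step touches this group: the only measured step alters configuration alone, and compounds 1 and 2 carry the cyano group together with a different chain, so their numbers cannot be tied to the cyano group by itself. The step of a 2.5-fold higher number from compound 3 to compound 4 (0.40 log units; beyond the scatter) is therefore an estimate resting on weak ground. Compound 4 is expected to give 900 nM in this assay, with a likely range from 300 nM to 2700 nM.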

Compound 4, half-maximal inhibitory concentration: 1100 nM
Compound 4: the middle estimate sits 1.2-fold (0.09 log units) below what was measured; low and high end bracket the measured number.
By their numbers in this assay, from the lowest: compound 3; then compounds 4, 1 and 2 (each within the scatter of the next, the first and the last beyond it).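

With the 1,1-dimethylpropyl chain held fixed, this aromatic carbon now has a direct comparison, and cyano in place of fluoro gives a 3.1-fold higher number from compound 3 to compound 4 (0.49 log units; beyond the scatter). With cyano kept, 1,1-dimethylpropyl in place of sec-butyl gives a 3.6-fold lower number from compound 2 to compound 4 (0.56 log units; beyond the scatter) but a 2.0-fold lower number from compound 1 to compound 4 (0.30 log units; within the scatter) and so clears the scatter from one starting compound only, and those two starting compounds are separated by one thing alone: the fact that compounds 1 and 2 differ only in the configuration as drawn. On these data alone, whether chloro or methoxy on this aromatic carbon would read closer to fluoro or to cyano stays open. So does how fluoro reads alongside a sec-butyl chain.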